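A few compounds are considered here, and "the series" means these few. Any claim that something is new, unique, unknown or untested is made for them only; others in the source may bear on it.

For the measured compounds named here, in a functional assay on SK-MEL-5 cells (Homo sapiens) for inhibition, read by sulforhodamine B assay, with a stated time of 48 h (a lower number here means a stronger inhibitor of growth, a higher number a weaker inhibitor of growth), two compounds sharing one core have numbers so far. Compound 1 `CN1CCCN(CCNc2nccc(-c3c(-c4cccc(O)c4)nc4sccn34)n2)S1(=O)=O` gives 10300 nM, and compound 2 `O=S(=O)(NCCCNc1nccc(-c2c(-c3cccc(O)c3)nc3sccn23)n1)c1cccc(F)c1` gives 2280 nM, the lower of the two. Compound 3 `O=S(=O)(NCCNc1nccc(-c2c(-c3cccc(O)c3)nc3sccn23)n1)c1ccc(F)cc1` has not yet been measured. Its difference from compound 2 is ((4-fluorophenyl)sulfonyl)amino in place of (((3-fluorophenyl)sulfonyl)amino)methyl on a saturated chain carbon, two bonds along the chain from a nitrogen on an aromatic ring. In words, ((4-fluorophenyl)sulfonyl)amino stands in place of (((3-fluorophenyl)sulfonyl)amino)methyl on a saturated chain carbon, two bonds along the chain from a nitrogen on an aromatic ring.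

Going by the values given here, only one measured step touches that place: a 4.5-fold lower number from compound 1 to compound 2 (0.65 log units; beyond the scatter), which is modest but beyond the scatter. That step brought in a six-membered aromatic ring of carbon only, in place of a six-membered non-aromatic ring with 3 hetero atoms. Compound 3 keeps such an aromatic ring, so no return towards the number of compound 1 10300 nM is expected. Among the compounds with values here, no measured step isolates the present, smaller change, so the expectation stays wide. No step beyond the scatter is expected, the estimate being a 1.2-fold higher number from compound 2 to compound 3 (0.09 log units; within the scatter). Compound 3 is expected at 2800 nM, with an estimated range of 1000 nM to 7500 nM.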

Compound 3, concentration for total growth inhibition: 3980 nM
Compound 3: the middle estimate sits 1.4-fold (0.15 log units) below what was measured; measured number inside the range.
By their numbers in this assay, from the lowest: compounds 2 and 3 (each within the scatter of the next); then compound 1.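

In this assay, the step of a 1.7-fold higher number from compound 2 to compound 3 (0.24 log units; within the scatter) lies within the scatter, so replacing (((3-fluorophenyl)sulfonyl)amino)methyl with ((4-fluorophenyl)sulfonyl)amino at this saturated chain carbon leaves the number essentially unchanged. The second step, a 2.6-fold lower number from compound 1 to compound 3 (0.41 log units; beyond the scatter), lies beyond the scatter, showing that the lower number seen for compound 2 against compound 1 is also seen with a second fluorophenyl sulfonylamino group of a different size and fluorine placement. No evidence is available to explain either step.

The compounds shown leave open what the chain length and the fluorine position each contribute alone, for these two features change together between compound 2 and compound 3, and the step between them cannot separate one from the other. They also leave open how this position would respond to a plain phenylsulfonylamino group carrying no fluorine, to a still longer chain ending in the 4-fluorophenyl sulfonylamino group, or to a simple amine at the end of the chain.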